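The source may hold more compounds than are shown below. What is called first, only, known or untested is meant among the compounds shown, and "the series" means these compounds.

Of the compounds shown here, three of a shared core have been measured so far. Compound 1 `COc1cc(C)cc(-c2c(-c3ccnc(-c4ccc(C(C)=O)cc4)c3)cnn2CC#N)c1` gives 2970 nM in a functional assay on CCRF-CEM cells (Homo sapiens) for inhibition, read by sulforhodamine B assay, with a stated time of 48 h; on this read-out higher numbers stand for weaker inhibition of growth and lower numbers for stronger inhibition of growth. Compound 2 `Cc1cc(O)cc(-c2nn(CC#N)cc2-c2ccnc(-c3ccc(Oc4ccccc4)cc3)c2)c1` gives 2850 nM in this assay. Compound 3 `COc1cc(C)cc(-c2nn(CC#N)cc2-c2ccnc(-c3ccc(N(C)C)cc3)c2)c1` gives 454 nM in this assay, the lowest of the three numbers; both compound 1 and compound 2 sit beyond the scatter above it, so compound 3 is the strongest grower-inhibitor among these three.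

Compound 4 `Cc1cc(O)cc(-c2nn(CC#N)cc2-c2ccnc(-c3ccc(N(C)C)cc3)c2)c1` has not yet been measured. It differs from compound 3 in one place only: hydrogen in place of methyl on an oxygen on an aromatic ring. Within the data shown here, no pair of measured compounds differs by this same single change, so there is no measured step to lean on; compounds 1 and 2 each differ from compound 3 in two places and only show their own values.

With no guide from a measured step, the change from compound 3 to compound 4 is expected to be small, a 1.3-fold higher number from compound 3 to compound 4 (0.12 log units; within the scatter), within the usual scatter. Compound 4 is therefore estimated to give 600 nM in this assay, with a likely range from 250 nM to 1500 nM.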

Compound 4, concentration for 50% growth inhibition: 3590 nM
Estimate against measurement, compound 4: 6.0-fold (0.78 log units) below; measured number outside the range, above it.
By their numbers in this assay, from the lowest: compound 3; then compounds 2, 1 and 4 (each within the scatter of the next).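

In this assay this position is sensitive: the small change from methoxy to hydroxy, which removes only one methyl, gives a 7.9-fold higher number from compound 3 to compound 4 (0.90 log units; beyond the scatter), so with dimethylamino held constant the methyl on this oxygen goes with stronger inhibition of growth. With hydroxy held constant, dimethylamino in place of phenoxy gives a 1.3-fold higher number from compound 2 to compound 4 (0.10 log units; within the scatter), so this pair shows no separation between those two groups. Nothing measured here explains the effect of the methyl on this oxygen.

From the compounds shown here alone, it remains open whether ethoxy, a longer chain on this oxygen, or an amine in place of methoxy would match or improve on compound 3. Going by these compounds, it is also open whether the step from methoxy to hydroxy keeps its size with phenoxy in place of dimethylamino.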